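A few compounds are considered here, and "the series" means these few. Any claim that something is new, unique, unknown or untested is made for them only; others in the source may bear on it.

Of the compounds shown here, two have been tested so far in a functional assay on Hepa cells (Homo sapiens) for cytotoxicity, with a stated time of 72 h (on this read-out lower numbers stand for an effect already at smaller amounts and higher numbers for an effect only at larger amounts of compound), and neither gives a number. Compound 1 `CO[C@@]12CC[C@H](O)[C@@](C)(CC[C@@H]3/C(=C\C=C\C(C)(C)O)COC(=O)[C@H]31)C2` gives > 20 ug/mL, which is a limit of the assay and not a number. Compound 2 `C=C1C(=O)[C@H](OC(=O)c2ccccc2)/C=C(\C)CC[C@@H]2C([C@H](OC(C)=O)[C@@H](C=C(C)C)OC(C)=O)=CO[C@@H](OC(C)=O)[C@@H]12` gives > 20 ug/mL, likewise a limit. Going by these compounds, the record therefore consists only of the limit of > 20 ug/mL in this assay, at which 2 of the 2 values shown sit, and the true position of compound 1 remains unknown.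

Compound 3 `CO[C@@]12CC[C@H](OC(C)=O)[C@@](C)(CC[C@@H]3/C(=C\C=C\C(C)(C)O)COC(=O)[C@H]31)C2` keeps the core of compound 1 and differs from it in one place. The difference reads as hydroxy to acetoxy: acetyl in place of hydrogen on an oxygen on a saturated carbon. For the measured compounds named here, no measured pair shows what this change does, so its size cannot be read from the data. In this assay, the expected result is a small step at most, towards an effect at smaller amounts, and compound 3 may well stop at the same limit. The expected change is an at least 1.1-fold lower number from compound 1 to compound 3 (0.04 log units; that floor lies within the scatter). For compound 3 the estimated value is 18 ug/mL, with an expected range from 6 ug/mL to 40 ug/mL.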

Compound 3, concentration for half-maximal effect: > 20 ug/mL
Compound 3 gave a limit, no number (the forecaster's own chance of this, stated with the estimate: 65%); middle value at least 1.1-fold (0.04 log units) away from the limit.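

In this assay, for the compounds shown here, compound 3 gives a limit and not a number, as compound 1 does, so no step between compound 1 and compound 3 can be read: the limit of > 20 ug/mL in this assay, at which 3 of the 3 values shown sit. The compounds shown leave open whether acetoxy in place of hydroxy changes the effect at all, and at what amounts any of them would act.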